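The compounds below may be only part of what the source reports. "The series", "measured", "known", "first", "only" and "open" are said of these compounds alone.

Compound 1 `O=C1c2ccccc2C(=O)N1C/C=C\Cn1cc(C#Cc2ccc(Br)cc2)c(=O)[nH]c1=O` was tested in a functional assay on HepG2 cells (Homo sapiens) for antiproliferative activity, read by MTT assay, with a stated time of 3 days (a higher number here means a weaker inhibitor, a lower number a stronger inhibitor), where compound 1 gives 89000 nM, the highest number of the three measured. Compound 2 `CCCCCCC#Cc1cn(C/C=C/CN2C(=O)c3ccccc3C2=O)c(=O)[nH]c1=O` gives 14000 nM in this assay, and compound 3 `CCCCCC#Cc1cn(C/C=C/CN2C(=O)c3ccccc3C2=O)c(=O)[nH]c1=O` gives 9000 nM. Among the measured compounds shown here, the one measured step, a 1.6-fold lower number from compound 2 to compound 3 (0.19 log units; within the scatter), shortens an alkyl chain and stays within the scatter. Compound 4 `CCCCc1ccc(C#Cc2cn(C/C=C\CN3C(=O)c4ccccc4C3=O)c(=O)[nH]c2=O)cc1` differs from compound 1 by butyl in place of bromo on an aromatic carbon. For the measured compounds named here, no measured step changes a group on this ring, so the step from compound 2 to compound 3 is the only guide, and it says little about adding a chain here. For compound 4 a small drop is expected, a 2.2-fold lower number from compound 1 to compound 4 (0.35 log units; beyond the scatter), with wide uncertainty. Compound 4 is therefore estimated at 40000 nM, within a range from 10000 nM to 150000 nM.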

Compound 4, half-maximal inhibitory concentration: 40000 nM
Estimate against measurement, compound 4: no gap at the digits printed; measured number inside the range.
By their numbers in this assay, from the lowest: compounds 3 and 2 (each within the scatter of the next); then compound 4; then compound 1.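

In this assay, replacing bromo with butyl on the aromatic ring gives a 2.2-fold lower number from compound 1 to compound 4 (0.35 log units; beyond the scatter). Among the compounds shown here, this is the first measured sign that the group on this ring can shift the number, though the shift is modest, and the earlier chain step showed nothing about this position. No measurement shown explains this step. On these data alone, whether an amine or a carboxylic acid here would shift the number further remains open, as does the effect of a chain longer than butyl.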